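Replacing a pyridinyl amide arm with a chloromethylphenyl arm

The source may hold more compounds than are shown below. What is called first, only, known or untested is meant among the compounds shown, and "the series" means these compounds.

The three measured compounds share one core, an amide whose nitrogen is linked through a methylene to a piperidine bearing a pyridine N-oxide; they differ only in the aryl group on the carbonyl carbon. Compound 1 `O=C(NCN1CCC(c2cccc[n+]2[O-])CC1)c1cnccc1Cl` carries a 4-chloropyridin-3-yl group and gives 44% in a functional assay on HEK293 cells for agonist activity at D(4) dopamine receptor (Homo sapiens), read by FLIPR; a higher number here means a larger maximal response, a lower number a smaller maximal response. Compound 2 `C=Cc1cccc(C(=O)NCN2CCC(c3cccc[n+]3[O-])CC2)c1`, with a 3-vinylphenyl group, gives 63% in this assay. Compound 3 `O=C(NCN1CCC(c2cccc[n+]2[O-])CC1)c1ccccn1`, with a pyridin-2-yl group, gives 40% in this assay, the lowest of the three numbers; its gap to compound 1 is within the scatter, while compound 2 lies clearly above it, the step being a number 23 percentage points lower from compound 2 to compound 3 (beyond the scatter).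

Compound 4 `Cc1cc(C(=O)NCN2CCC(c3cccc[n+]3[O-])CC2)ccc1Cl` is the next member. The change from compound 3 is 4-chloro-3-methylphenyl in place of pyridin-2-yl on a carbonyl carbon.

Among the measured compounds shown here, two measured steps bear on this. The step of a number 23 percentage points lower from compound 2 to compound 3 (beyond the scatter) shows that swapping a substituted phenyl for pyridin-2-yl lowered the response, so the reverse direction here should raise it. The step of a number 19 percentage points higher from compound 1 to compound 2 (beyond the scatter) shows a phenyl group outperforming a halogenated pyridinyl group by a modest margin. Both point the same way, so a modest increase beyond the scatter is expected for compound 4, the step from compound 3 being estimated as a number 18 percentage points higher from compound 3 to compound 4 (beyond the scatter). Compound 4 is therefore expected to give about 58%, within a range of 40% to 76%.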

Compound 4, largest response reached (reported as efficacy), in percent of the reference or control that the assay uses: 62%
Beside the measured number, compound 4's estimate is 4 percentage points below it, within the range that was stated.
By their numbers in this assay, from the lowest: compounds 3 and 1 (each within the scatter of the next); then compounds 4 and 2 (each within the scatter of the next).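

In this assay, 4-chloro-3-methylphenyl in place of pyridin-2-yl on the carbonyl carbon gives a clear gain (a number 22 percentage points higher from compound 3 to compound 4 (beyond the scatter)), and the same group in place of 4-chloropyridin-3-yl gives a gain of similar size (a number 18 percentage points higher from compound 1 to compound 4 (beyond the scatter)). Against the other arm with a carbon-only ring, the step (a number 1 percentage points lower from compound 2 to compound 4 (within the scatter)) does not separate 4-chloro-3-methylphenyl from 3-vinylphenyl, so a second, differently substituted phenyl arm now stands with compound 2, and among these four compounds both phenyl arms lie clear of both pyridinyl arms, with none going against that split. Nothing measured here explains this split between the arms.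

The compounds shown leave open whether an unsubstituted phenyl, or a phenyl carrying only the chlorine or only the methyl, gives a response like that of compound 4. They also leave open how a carboxylic acid or an amine on the phenyl arm would read in this assay, and what a longer chain in place of the methylene linker would do.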